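The source may report more compounds than this note shows. Statements on the series, on what has been measured and on what is new or still open speak of the compounds shown alone.

For the measured compounds named here, in a functional assay on MCF7 cells (Homo sapiens) for inhibition, read by sulforhodamine B assay, with a stated time of 48 h (a lower number here means a stronger inhibitor of growth, a higher number a weaker inhibitor of growth), compound 2 (`COc1ccc2c(c1)NC(=O)CN2c1nc(NCc2ccncc2)nc2ccccc12`) gives 71.8 nM, the lower of the two numbers measured so far. Going by the values given here, the only other measured compound, compound 1 (`COc1ccc2c(c1)NC(=O)CN2c1nc(COCCCC(=O)NO)nc2ccccc12`), gives 1210 nM. These two differ in one place, and the step is a 17-fold lower number from compound 1 to compound 2 (1.23 log units; beyond the scatter). Compound 3 (`CCCCNc1nc(N2CC(=O)Nc3cc(OC)ccc32)c2ccccc2n1`) keeps the shared core and changes only the end of the side chain of compound 2: propyl in place of pyridin-4-yl on a saturated chain carbon bound to a nitrogen on an aromatic ring. Propyl stands in place of pyridin-4-yl, so ((pyridin-4-yl)methyl)amino becomes butylamino. Among the compounds with values here, the one measured step replaced a different group at this place on the core. It shows that the number can move strongly here, but it does not show the direction for this new change. A modest rise, smaller than that step, is expected, and the estimated step is a 2.1-fold higher number from compound 2 to compound 3 (0.32 log units; beyond the scatter). For compound 3 the expected value is 150 nM, within a range of 40 nM to 600 nM.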

Compound 3, concentration for 50% growth inhibition: 7.88 nM
The estimate for compound 3 lay 19-fold (1.28 log units) above the measured number, outside the stated range (below it).
By their numbers in this assay, from the lowest: compound 3; then compound 2; then compound 1.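

In this assay the end of this side chain matters in its own right: with the amino link kept, propyl in place of pyridin-4-yl gives a 9.1-fold lower number from compound 2 to compound 3 (0.96 log units; beyond the scatter). For this pair, then, an aromatic ring at the chain end is not required for a low number, and the plain chain gives the lower one. The full change to butylamino on the aromatic carbon gives a 150-fold lower number from compound 1 to compound 3 (2.19 log units; beyond the scatter), a larger drop than compound 2 had shown, though nothing available explains the gain.

Going by these compounds, whether a shorter chain such as ethylamino or a chain longer than butyl would lower the number further remains open. So does the effect of an amine or a carboxylic acid at the end of the butyl chain.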